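Swapping Fluoro for Nitro on a Weakly Characterised Ring

The compounds below may be only part of what the source reports. "The series", "measured", "known", "first", "only" and "open" are said of these compounds alone.

In a functional assay on MCF7 cells (Homo sapiens) for antiproliferative activity, read by MTT assay, with a stated time of 24 h (a higher number here means a weaker inhibitor, a lower number a stronger inhibitor), compound 2 `Cc1cccc(Nc2ncc(Br)c(Oc3cccc(F)c3)n2)c1` gives 26800 nM and compound 1 `CNC(=O)c1ccccc1Oc1nc(Nc2cccc(OC)c2)ncc1Br` gives 18200 nM as its value, two numbers that lie within the usual scatter of each other. Compound 3 `Cc1cccc(Nc2ncc(Br)c(Oc3cc(Cl)cc(Cl)c3)n2)c1` returns > 50000 nM as its reading, which is a limit of the assay and not a number.

Compound 4 `Cc1cccc(Nc2ncc(Br)c(Oc3cccc([N+](=O)[O-])c3)n2)c1` keeps everything in compound 2 except one group, with nitro in place of fluoro on an aromatic carbon as the counted change: nitro in place of fluoro on an aromatic carbon, meta to a large group.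

Within the data shown here, only one measured step bears on this change, and it is a different swap on the same ring. With only an at least 1.8-fold higher number from compound 2 to compound 3 (0.27 log units; that floor lies within the scatter) to go on, when 3,5-dichlorophenyl takes the place of 3-fluorophenyl, no step beyond the scatter is expected in this assay for compound 4, perhaps a slight drift to a higher number. That step gives only a floor and no firm size, and no measurement exists here for nitro itself.

The expected move is a 1.1-fold higher number from compound 2 to compound 4 (0.05 log units; within the scatter) on this estimate. Compound 4 is estimated at 30000 nM with an expected range of 12000 nM to 50000 nM for its value.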

Compound 4, half-maximal inhibitory concentration: > 50000 nM
Compound 4: no number, only a limit; the forecaster's own chance of this, stated with the estimate: 25%; middle value at least 1.6-fold (0.22 log units) from the limit.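

In this assay, the change from fluoro to nitro gives an at least 1.8-fold higher number from compound 2 to compound 4 (0.27 log units; that floor lies within the scatter), so this step has a floor and no firm size. Compound 4 gives > 50000 nM, which is a limit of the assay and not a number. Before this result, only the 3,5-dichlorophenyl swap had been tested against compound 2; now a second, different replacement on the same ring also ends at the limit, yet compound 3 and compound 4 cannot be ranked against each other, because neither reading gives an actual number: the limit of > 50000 nM in this assay, at which 2 of the 4 values shown sit.

The compounds shown leave open whether any group on this aromatic carbon can give a lower number than fluoro does, since neither step away from compound 2 has a size that lies firmly beyond the scatter. An amine or a carboxylic acid in place of fluoro, keeping the rest of compound 2 unchanged, would put a different kind of group at this spot and might give a reading that falls short of the limit and can be compared directly.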